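This account rests on a few compounds, and the source may have more. Where it says the series, first, only, none or still open, it means among the compounds named here.

In a functional assay on MDA-MB-231 cells (Homo sapiens), read by wound healing assay, with a stated time of 24 h (on this read-out higher numbers stand for weaker inhibition and lower numbers for stronger inhibition), compound 1 `CC(C)=CCC[C@H](C)c1ccc(C)c(CNCCO)c1O` gives > 20000 nM, which is a limit and not a number. That places it at the limit of > 20000 nM in this assay, at which 1 of the 3 values shown sits, so no exact starting value exists. Compound 2 `CC(C)=CCC[C@H](C)c1ccc(C)c2c1OCN(CCCCCO)C2` gives 10000 nM in this test, and compound 3 `CC(C)=CCC[C@H](C)c1ccc(C)c2c1OCN(CCCCC(=O)O)C2` gives 29900 nM here. Compound 4 `CC(C)=CCC[C@H](C)c1ccc(C)c(CNCCCCC(=O)O)c1O` carries 2-carboxyethyl in place of hydroxy on a saturated chain carbon, two bonds along the chain from an amine nitrogen. The nearest measured change, which also ends a chain in carboxy, shows a 3.0-fold higher number from compound 2 to compound 3 (0.48 log units; beyond the scatter) on the ring-closed compounds. A similar modest shift towards weaker inhibition is therefore expected, namely a step that the limit leaves unreadable from compound 1 to compound 4 in this assay as an estimate. Compound 4 is estimated at 32000 nM with a range from 14000 nM to 70000 nM as expected values.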

Compound 4, half-maximal inhibitory concentration: > 20000 nM
Compound 4: only a limit was reported; the forecaster's own chance of this, stated with the estimate: 45%; the middle value does not contradict the limit.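

Going by these compounds alone, compound 1 and compound 4 are both reported only as limits, not numbers, so no step between them can be read, because both sit at the same limit: the limit of > 20000 nM in this assay, at which 2 of the 4 values shown sit. From the compounds shown here alone, whether (4-carboxybutyl)amino in place of (2-hydroxyethyl)amino changes inhibition on the core of compound 1 stays open.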